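Pyrazole nitrogen demethylation in a series with low inhibition numbers

The source may hold more compounds than are shown below. What is called first, only, known or untested is meant among the compounds shown, and "the series" means these compounds.

Three members of the series have been measured in an assay on isolated protein for inhibition of RAC-beta serine/threonine-protein kinase (Homo sapiens), read by mobility shift assay, tested at 30 uM; a lower number here means less inhibition, a higher number more inhibition at the concentration tested (going by the name of the read-out). Compound 1 `COc1cccc(-c2cc3[nH]nc(N)c3c(=O)[nH]2)c1` gives 2% in this assay. Compound 2 `COc1cccc(-c2cc3c(c(N)nn3C)c(=O)[nH]2)c1` gives 1%. Compound 3 `Cc1cc2c(cn1)c(N)nn2C` gives -2%; how its core differs from that of compound 2 is not broken down here. Going by the values given here, the one counted change is hydrogen in place of methyl on an aromatic nitrogen, which in this assay made a step of a number 1 percentage points higher from compound 2 to compound 1 (within the scatter).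

Compound 4 `Cc1cc2[nH]nc(N)c2cn1` is not yet measured. It carries the same change relative to compound 3, (hydrogen in place of methyl on an aromatic nitrogen). Because the measured step of a number 1 percentage points higher from compound 2 to compound 1 (within the scatter) lies within the scatter and compound 3 sits at -2%, the expected step is a number 2 percentage points higher from compound 3 to compound 4 (within the scatter), near no change. Compound 4 is therefore estimated at 0% in this assay, between -10% and 10%.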

Compound 4, a percentage reported as inhibition, at one concentration (the size of the read-out at that concentration, not a potency): -3%
The estimate for compound 4 lay 3 percentage points above the measured number; the range from low to high includes it.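

In this assay, hydrogen in place of methyl on an aromatic nitrogen gave a number 1 percentage points lower from compound 3 to compound 4 (within the scatter). Going by these compounds alone, on the two cores, the change behaves alike within the limits of this read-out: the same change on two cores in this assay, a number 1 percentage points higher (within the scatter) from compound 2 to compound 1 and a number 1 percentage points lower (within the scatter) from compound 3 to compound 4, 2 percentage points apart, within the scatter of two such steps This shows only that the change produced no readable step on either core, with all four compounds giving low numbers; it does not show how the change would carry over to a compound with clear inhibition at the concentration tested.

On these data alone, the effect of an ethyl group or a longer chain on that nitrogen remains open. So does the effect of replacing the amino group with an amide or a carboxylic acid.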